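Swapping an octyl chain for phenyl: stability outlook

A few compounds are considered here, and "the series" means these few. Any claim that something is new, unique, unknown or untested is made for them only; others in the source may bear on it.

Of the compounds shown here, three sharing one core have been measured in an ADME assay on S9 fraction from liver (Rattus norvegicus) for metabolic stability, read by LC-MS, using NADPH, with a stated time of 30 min; on this read-out lower numbers stand for a less stable compound and higher numbers for a more stable compound. Compound 1 `CCCCCCCCc1ccc(OC(C)C(=O)Cn2nnc(-c3ccccc3)n2)cc1` gives 40%. Compound 2 `CCCCCCCCc1ccc(OC(C)C(=O)Cn2nnc(-c3ccc(C(=O)OC)cc3)n2)cc1` gives 62%. Compound 3 `CCCCCCCCc1ccc(OC(C)C(=O)Cn2nnc(-c3ccc(C(=O)O)cc3)n2)cc1` gives 55%. The measured steps are a number 22 percentage points higher from compound 1 to compound 2 (beyond the scatter), a number 15 percentage points higher from compound 1 to compound 3 (beyond the scatter) and a number 7 percentage points lower from compound 2 to compound 3 (within the scatter). Compound 3 therefore stands second highest of the three numbers, within the scatter of compound 2 and beyond the scatter above compound 1.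

Compound 4 `CC(Oc1ccc(-c2ccccc2)cc1)C(=O)Cn1nnc(-c2ccc(C(=O)O)cc2)n1` differs from compound 3 at the far end of the core: phenyl in place of octyl on an aromatic carbon. Going by the values given here, none of the measured steps touches this part of the molecule; all three concern the group on the other aromatic ring. Among the compounds with values here, there is thus no measured step that bears directly on this change, and the direction of any shift cannot be read from the numbers at hand. The expectation is a step of a number 3 percentage points higher from compound 3 to compound 4 (within the scatter), that is, no change beyond the scatter. Compound 4 is estimated at 58% in this assay, with a range from 33% to 83%.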

Compound 4, percent of the compound remaining: 30%
Compound 4: middle estimate off by 28 percentage points, on the high side; measured number below the stated range.
By their numbers in this assay, from the lowest: compounds 4 and 1 (each within the scatter of the next); then compounds 3 and 2 (each within the scatter of the next).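

Moving to the far end of the core, the swap of octyl for phenyl gives a number 25 percentage points lower from compound 3 to compound 4 (beyond the scatter) in this assay. Going by these compounds alone, this shows that the position on an aromatic carbon, para to a large group, also affects the read-out, whereas the earlier steps only changed the group on the other aromatic ring. The data offer no measured explanation for why this swap lowers the number.

The compounds shown leave open whether the ring or the loss of the chain matters more, since a shorter chain such as butyl or a non-aromatic ring such as cyclohexyl could separate the two. As far as these compounds go, it is also open whether phenyl in place of octyl gives a similar step when the carboxy group is replaced by the methyl ester or by hydrogen.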